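Oxazolidinone series: sulfonamide replaced by an ethylurea

The source may hold more compounds than are shown below. What is called first, only, known or untested is meant among the compounds shown, and "the series" means these compounds.

Measured compounds and values:
compound 1, `O=C1O[C@@H](CN2CCCCC2)CN1c1ccc(-n2cc(-c3ccccn3)cn2)c(F)c1`, 3.1
compound 2, `COC[C@H]1CN(c2ccc(-n3cc(-c4ccccn4)cn3)c(F)c2)C(=O)O1`, 2.18
compound 3, `CS(=O)(=O)NC[C@H]1CN(c2ccc(-n3cc(-c4ccccn4)cn3)c(F)c2)C(=O)O1`, 1.38

In a physicochemical assay for lipophilicity, read by HPLC, measured as octanol-water partition (a lower number here means a more polar compound, a higher number a more lipophilic compound), compound 3 gives the lowest of the three numbers; compound 2 is the nearest above it and compound 1 the furthest. The steps that lead there are a number 0.92 log units lower from compound 1 to compound 2 (beyond the scatter), a number 0.80 log units lower from compound 2 to compound 3 (beyond the scatter) and a number 1.72 log units lower from compound 1 to compound 3 (beyond the scatter), all on the saturated chain carbon bound to the saturated ring carbon of the shared core.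

Compound 4, `CCNC(=O)NC[C@H]1CN(c2ccc(-n3cc(-c4ccccn4)cn3)c(F)c2)C(=O)O1`, differs from compound 3 in one place: ethylcarbamoyl in place of methylsulfonyl on an amine nitrogen. Going by the values given here, none of the measured steps covers this exact exchange; each of them replaced the whole group on that chain carbon rather than one part of it, so the bearing of those steps on compound 4 is indirect. The group that leaves and the group that enters are close in size, and the tally of donors and acceptors changes by a single unit in each direction. The expected step in this assay is therefore small, a number 0.22 log units higher from compound 3 to compound 4 (within the scatter), close to or within the scatter and, if anything, upward. Compound 4 is estimated at 1.6, with a range from 1.1 to 2.1.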

Compound 4, partition coefficient: 2.45
Compound 4: middle estimate off by 0.85 log units, on the low side; the whole stated range lies below it.
By their numbers in this assay, from the lowest: compound 3; then compounds 2 and 4 (each within the scatter of the next); then compound 1.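

Going by these compounds alone, on the amine nitrogen, in this assay, ethylcarbamoyl in place of methylsulfonyl is a large step in its own right (a number 1.07 log units higher from compound 3 to compound 4 (beyond the scatter)), although the earlier steps at this position had exchanged the whole group on the saturated chain carbon and this one exchanges only the part on the nitrogen. With that nitrogen kept, (ethylcarbamoyl)amino cannot be told apart from methoxy (a number 0.27 log units higher from compound 2 to compound 4 (within the scatter)) and still stands clear of piperidin-1-yl (a number 0.65 log units lower from compound 1 to compound 4 (beyond the scatter)), so the methanesulfonamido group of compound 3 alone holds the low end of this set, and groups with closely matched atom and donor-acceptor counts can differ widely at this place. Nothing measured here accounts for the size of the step.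

Open, from the compounds shown here alone, is how much of the step rests on the ethyl part of ethylcarbamoyl and how much on the carbonyl: a methylcarbamoyl or an acetyl group on the same amine nitrogen would separate the two. Also open, going by these compounds, is how a longer chain on the sulfonyl, such as ethylsulfonyl, would read against compound 3 and compound 4.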